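Pyridin-2-yl to pyrazin-2-yl on a shared thiazolopyrimidine-free core

A few compounds are considered here, and "the series" means these few. Any claim that something is new, unique, unknown or untested is made for them only; others in the source may bear on it.

Measured so far:
- compound 1, `Nc1nc(NCc2ccncc2)nc2sc(-c3ccco3)nc12`: in an assay on CHO cells for displacement of a labelled ligand from adenosine receptor A3 (Homo sapiens), read by scintillation counting, with a stated time of 120 min (on this read-out lower numbers stand for stronger inhibition and higher numbers for weaker inhibition), compound 1 gives 827 nM
- compound 2, `Nc1nc(NCc2ccccn2)nc2sc(-c3ccco3)nc12`: in this assay compound 2 gives 59 nM

Compound 2 stands as the lowest of the two numbers in this assay; its nearest neighbour is compound 1, and the step of a 14-fold lower number from compound 1 to compound 2 (1.15 log units; beyond the scatter) separates them, a large change for the move of the ring nitrogen from pyridin-4-yl to pyridin-2-yl.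

Compound 3, `Nc1nc(NCc2cnccn2)nc2sc(-c3ccco3)nc12`, has not yet been measured. It differs from compound 2 in one place: pyrazin-2-yl in place of pyridin-2-yl on a saturated chain carbon bound to a nitrogen on an aromatic ring. Going by the values given here, the only measured step that bears on this change is a 14-fold lower number from compound 1 to compound 2 (1.15 log units; beyond the scatter), which shows that the ring attached to the saturated chain carbon is a sensitive position. Compound 3 keeps the pyridin-2-yl arrangement of compound 2 and adds what the pyrazin-2-yl ring counts, so the author expects at most a modest change in this assay, somewhat toward a higher number, with the estimated step of a 1.5-fold higher number from compound 2 to compound 3 (0.18 log units; within the scatter). For compound 3 the author estimates 90 nM, within a range from 30 nM to 300 nM.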

Compound 3, inhibition constant: 157 nM
The estimate for compound 3 lay 1.7-fold (0.24 log units) below the measured number; the range from low to high includes it.
By their numbers in this assay, from the lowest: compound 2; then compound 3; then compound 1.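

In this assay the step of a 2.7-fold higher number from compound 2 to compound 3 (0.43 log units; beyond the scatter) shows that this position responds to a change in the ring even when the pyridin-2-yl arrangement is kept: pyrazin-2-yl, with 2 hetero atoms and 2 hydrogen-bond acceptors where pyridin-2-yl has 1 of each, is not a neutral replacement. The same ring still compares well with pyridin-4-yl, as the step of a 5.3-fold lower number from compound 1 to compound 3 (0.72 log units; beyond the scatter) shows, so on a saturated chain carbon bound to a nitrogen on an aromatic ring the three rings now fall in a graded order, with pyrazin-2-yl in the middle. The change to pyrazin-2-yl thus gives back only part of the gain seen in a 14-fold lower number from compound 1 to compound 2 (1.15 log units; beyond the scatter) and does not undo it. Nothing available here explains why the number moves this way.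

As far as these compounds go, whether a plain phenyl ring, with no ring nitrogen at all, or a pyrimidin-2-yl ring would fall lower or higher than these three remains open. So does whether a longer chain in place of the methyl link would preserve the same order among the rings.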